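Swapping a pyrazole for a methylpyridine on the side-chain

The source may hold more compounds than are shown below. What is called first, only, known or untested is meant among the compounds shown, and "the series" means these compounds.

Measured compounds:
- compound 1 `Cc1cn2c(-c3cn[nH]c3)cnc2c(Nc2cc(Cn3cccn3)ns2)n1`: "not determined" (no result reported)
- compound 2 `Cc1cn2c(-c3cn[nH]c3)cnc2c(Nc2cc(Cc3ccccn3)ns2)n1`: 6880 ng.h/mL
- compound 3 `Cc1cn2c(-c3cn[nH]c3)cnc2c(Nc2cc(Cc3cccnc3)ns2)n1`: "not determined" (no result reported)

In an ADME assay on the whole organism for pharmacokinetics, with Rattus norvegicus as the target, with a stated time of 6 h, at a dose of 10 mg/kg by the oral route (on this read-out higher numbers stand for higher exposure at the dose given and lower numbers for lower exposure), compound 1 has no number, with the entry "not determined" (no result reported), and compound 3 likewise has none, with the entry "not determined" (no result reported), so only compound 2 gives a value in this assay, namely 6880 ng.h/mL. Compound 4 `Cc1ccc(Cc2cc(Nc3nc(C)cn4c(-c5cn[nH]c5)cnc34)sn2)nc1` has not yet been tested in this assay. It differs from compound 1 by 5-methylpyridin-2-yl in place of 1H-pyrazol-1-yl on a saturated chain carbon bound to an aromatic carbon. For the measured compounds named here, no measured step connects compound 1 to any other compound, so no direction or size can be read from the data. Going by the values given here, compound 2 carries a group on the same saturated chain carbon that closely resembles the one entering in compound 4, which makes an exposure of similar magnitude the most plausible expectation. Compound 4 is estimated to give 5000 ng.h/mL, expected to lie between 1500 ng.h/mL and 15000 ng.h/mL.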

Compound 4, area under the concentration-time curve: 1370 ng.h/mL
The estimate for compound 4 lay 3.6-fold (0.56 log units) above the measured number; measured number below the stated range.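

In this assay there is a 5.0-fold lower number from compound 2 to compound 4 (0.70 log units; beyond the scatter) for one added methyl on the pyridine ring. For the compounds shown here, this is the first comparison at this position, and it shows that even a change this small on the side-chain can lower oral exposure in the rat. Nothing available explains the drop.

Whether the pyrazole of compound 1 or the pyridin-3-yl group of compound 3 would give more or less exposure cannot be read. A chlorine atom or a methoxy group in place of the methyl also remains an open case.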